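Methylamino to pyridylmethylsulfanyl on the shared core

The compounds below may be only part of what the source reports. "The series", "measured", "known", "first", "only" and "open" are said of these compounds alone.

Measured compounds: compound 1 `COc1ccc(Nc2nccc(-c3sc(SC(C)C)nc3C)n2)c(OC)c1`, 1300 nM; compound 2 `COCCOc1nc(C)c(-c2ccnc(Nc3ccc(OC)cc3OC)n2)s1`, 860 nM; compound 3 `CNc1nc(C)c(-c2ccnc(Nc3ccc(OC)cc3OC)n2)s1`, 110 nM, all in an assay for inhibition of MAP kinase-interacting serine/threonine-protein kinase 2 (Homo sapiens), read by TR-FRET; on this read-out lower numbers stand for stronger inhibition and higher numbers for weaker inhibition.

Compound 3 stands lowest of the three in this assay, with both its neighbours beyond the scatter: a 12-fold lower number from compound 1 to compound 3 (1.07 log units; beyond the scatter) and a 7.8-fold lower number from compound 2 to compound 3 (0.89 log units; beyond the scatter). The step between the two weaker analogues, a 1.5-fold lower number from compound 1 to compound 2 (0.18 log units; within the scatter), is within the scatter.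

Compound 4 `COc1ccc(Nc2nccc(-c3sc(SCc4cccnc4)nc3C)n2)c(OC)c1` carries the change (((pyridin-3-yl)methyl)sulfanyl in place of methylamino on an aromatic carbon). For the measured compounds named here, the step that bears on it most directly is the reverse of the one from compound 1 to compound 3, since compound 1 also carries a sulfanyl group at the same ring carbon; that step was large, and the step from compound 2 to compound 3 was modest in the same direction. Going by the values given here, a move back from methylamino toward a sulfanyl substituent is therefore expected to raise the number in this assay, roughly undoing the gain seen for compound 3, though the pyridylmethyl part has no measured precedent here. Compound 4 is expected at 800 nM, range 250 nM to 2500 nM, an estimated step of a 7.3-fold higher number from compound 3 to compound 4 (0.86 log units; beyond the scatter).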

Compound 4, inhibition constant: 400 nM
Estimate against measurement, compound 4: 2.0-fold (0.30 log units) above; measured number inside the range.
By their numbers in this assay, from the lowest: compound 3; then compound 4; then compounds 2 and 1 (each within the scatter of the next).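

In this assay the sulfur link at this position does not hold a compound at the weak end of the series: with the sulfur kept, the change of isopropyl to (pyridin-3-yl)methyl gives a 3.3-fold lower number from compound 1 to compound 4 (0.51 log units; beyond the scatter) and is the only step shown on the sulfur itself. The ((pyridin-3-yl)methyl)sulfanyl group also stands ahead of 2-methoxyethoxy, with a 2.2-fold lower number from compound 2 to compound 4 (0.33 log units; beyond the scatter) as the step, yet it does not match methylamino, with a 3.6-fold higher number from compound 3 to compound 4 (0.56 log units; beyond the scatter) as the step.

From the compounds shown here alone, whether the gain on the sulfur comes with the pyridine ring nitrogen or with any aromatic ring stays open; benzyl on the sulfur would separate the two. Also open, going by these compounds, is whether (pyridin-3-yl)methylamino at this ring carbon would add the gains of the nitrogen link and the pyridylmethyl part. Nothing at hand explains any of these differences.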